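Hydroxypropyl Chain in Place of the Branched Alkyl

This account rests on a few compounds, and the source may have more. Where it says the series, first, only, none or still open, it means among the compounds named here.

Compound 1 `CCCCCC(C)Nc1cc(Oc2c(OC)cc3cc(C#N)ccc3c2OC)nc(Nc2ccc(C#N)cc2)n1` shows no measurable toxicity in an ADME assay on MT4 cells (Homo sapiens) for cytotoxicity, read by MTT assay, with a stated time of 5 days; on this read-out higher numbers stand for lower toxicity in this test and lower numbers for higher toxicity in this test; compound 1 reaches only the assay limit, > 125000 nM. Compound 3 `COc1cc2cc(C#N)ccc2c(OC)c1Oc1cc(NCCCO)nc(Nc2ccc(C#N)cc2)n1` differs from it by 3-hydroxypropyl in place of 1-methylhexyl on a nitrogen on an aromatic ring. Among the compounds with values here, the one measured step at this position is a step that the two limits leave unreadable from compound 1 to compound 2. There compound 2 `COc1cc2cc(C#N)ccc2c(OC)c1Oc1cc(NCC2CC2)nc(Nc2ccc(C#N)cc2)n1` likewise gives only a limit in this assay, > 125000 nM. Because both values sit at the limit of > 125000 nM in this assay, at which 2 of the 2 values shown sit, the step to compound 3 cannot be sized from them. Compound 3 is expected to stay at the limit, with an expected step that the limit leaves unreadable from compound 1 to compound 3. Compound 3 is therefore estimated at 150000 nM, between 60000 nM and 400000 nM.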

Compound 3, half-maximal cytotoxic concentration: 23500 nM
Beside the measured number, compound 3's estimate is 6.4-fold (0.81 log units) above it; the whole stated range lies above it.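

This position is not silent in this assay: with 3-hydroxypropyl on the nitrogen, the read-out falls to a measurable number, with an at least 5.3-fold lower number from compound 1 to compound 3 (0.72 log units; beyond the scatter). Against the cyclopropylmethyl compound the change gives an at least 5.3-fold lower number from compound 2 to compound 3 (0.72 log units; beyond the scatter). Compound 3 thus stands apart from the two compounds that stay at the limit: the limit of > 125000 nM in this assay, at which 2 of the 3 values shown sit.

On these data alone, whether the step goes with the hydroxy group or with the chain itself stays open. A plain propyl chain or a 3-aminopropyl chain on the same nitrogen would bear on that question.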